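A few compounds are considered here, and "the series" means these few. Any claim that something is new, unique, unknown or untested is made for them only; others in the source may bear on it.

Measured so far in an assay on isolated protein for inhibition of protein deacetylase HDAC6 (Homo sapiens), read by fluorescence, with stated times of 10 min and 30 min, tested at 10 uM; a lower number here means less inhibition, a higher number more inhibition at the concentration tested (going by the name of the read-out):

Compound 1, `CCOc1cc(NC(=O)CCCCC(=O)Nc2cc(-c3ccccc3)ccc2N)cc2c1OCC([N+](=O)[O-])=C2`: 25%
Compound 2, `CCOc1cc(NC(=O)CCCCCCC(=O)Nc2cc(-c3ccccc3)ccc2N)cc2c1OCC([N+](=O)[O-])=C2`: 29%
Compound 3, `CCOc1cc(NC(=O)CCCCCCC(=O)Nc2ccccc2N)cc2c1OCC([N+](=O)[O-])=C2`: 52%

Among these three, compound 3 gives the highest inhibition in this assay; compound 2 sits nearer to it and compound 1 furthest, both beyond the scatter. Compound 4, `CCOc1cc(NC(=O)CCCCCCC(=O)Nc2cc(-c3ccc(C)s3)ccc2N)cc2c1OCC([N+](=O)[O-])=C2`, is the unmeasured one. It differs from compound 3 by 5-methylthiophen-2-yl in place of hydrogen on an aromatic carbon.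

Within the data shown here, only one measured step bears on this change. Going a number 23 percentage points higher from compound 2 to compound 3 (beyond the scatter), where hydrogen took the place of phenyl on an aromatic carbon, inhibition rose by a modest but real amount. The step to compound 4 runs the other way, putting an aromatic ring back in place of hydrogen, though a different ring, 5-methylthiophen-2-yl rather than phenyl. Because that earlier step was a number 23 percentage points higher from compound 2 to compound 3 (beyond the scatter), a drop of about the same size is expected here, giving an estimated a number 22 percentage points lower from compound 3 to compound 4 (beyond the scatter). Compound 4 is therefore expected to give about 30%, within a range of 15% to 48%.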

Compound 4, a percentage reported as inhibition, at one concentration (the size of the read-out at that concentration, not a potency): 19%
For compound 4 the middle estimate is 11 percentage points above the measured one, within the range that was stated.
By their numbers in this assay, from the lowest: compounds 4, 1 and 2 (each within the scatter of the next); then compound 3.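

In this assay, the drop seen when phenyl occupied this site also appears with a different aromatic ring, a five-membered one carrying sulfur and a methyl group (a number 33 percentage points lower from compound 3 to compound 4 (beyond the scatter)). The lower number is therefore not peculiar to phenyl. Exchanging one ring for the other at this carbon, para to the amino group, produces no change that can be separated from the scatter (a number 10 percentage points lower from compound 2 to compound 4 (within the scatter)), so these two rings cannot be told apart in this measurement.

Nothing available explains why either ring gives less inhibition than hydrogen here. The compounds shown also leave open how much room this position allows: a single methyl group, a fluorine atom or a pyridine ring might stay close to compound 3 or fall with the two rings.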